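Adding a Methoxy Group: From Measured Pairs to a Forecast

A few compounds are considered here, and "the series" means these few. Any claim that something is new, unique, unknown or untested is made for them only; others in the source may bear on it.

Measured in a functional assay on the whole organism (strain Swiss albino) with Mus musculus as the target, in the forced swim test, with a stated time of 5 min, at a dose of 0.5 mg/kg by the intraperitoneal route; on this read-out lower numbers stand for less inhibition and higher numbers for more inhibition at the one dose given (going by the name of the read-out):
- compound 1, `CCC(C)c1cc(C2C(C#N)=C(N)OC3=C2C(=O)CC(C)(C)C3)cc2cc(-c3ccc(OC)c(OC)c3)c(=O)oc12`, gives 57.4%
- compound 2, `CCC(C)c1cc(C2C(C#N)=C(N)OC3=C2C(=O)CC(C)(C)C3)cc2cc(-c3cc(OC)c(OC)c(OC)c3)c(=O)oc12`, gives 28.2%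
- compound 3, `COc1ccc(-c2cc3cc(C4C(C#N)=C(N)OC5=C4C(=O)CCC5)cc(C(C)(C)C)c3oc2=O)cc1OC`, gives -16.6%

Compound 1 and compound 2 differ in one place only: methoxy in place of hydrogen on an aromatic carbon. In this assay this change gave a number 29.2 percentage points lower from compound 1 to compound 2 (beyond the scatter). Compound 3 has a different core; how the two cores differ is not broken down here. Compound 3 stands lowest of the three, beyond the scatter from both others.

Compound 4, `COc1cc(-c2cc3cc(C4C(C#N)=C(N)OC5=C4C(=O)CCC5)cc(C(C)(C)C)c3oc2=O)cc(OC)c1OC`, is not yet measured. It differs from compound 3 by methoxy in place of hydrogen on an aromatic carbon, the same change as between compound 1 and compound 2, with the same surroundings. Resting on a number 29.2 percentage points lower from compound 1 to compound 2 (beyond the scatter), a similar downward step is expected, though the different core makes the size uncertain, so for compound 4 the estimated step is a number 18.4 percentage points lower from compound 3 to compound 4 (beyond the scatter), giving an expected value of -35%, between -75% and 5%.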

Compound 4, a percentage reported as inhibition, in the whole organism at one dose (the size of the read-out at that dose, not a potency): 5.33%
Beside the measured number, compound 4's estimate is 40.3 percentage points below it; measured number outside the range, above it.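

In this assay, going from 3,4-dimethoxyphenyl to 3,4,5-trimethoxyphenyl gave a number 21.9 percentage points higher from compound 3 to compound 4 (beyond the scatter). The same added methoxy therefore moved the read-out in opposite directions on the two cores, so the step seen on one core could not be carried over to the other: the same change on two cores in this assay, a number 29.2 percentage points lower (beyond the scatter) from compound 1 to compound 2 and a number 21.9 percentage points higher (beyond the scatter) from compound 3 to compound 4, 51.1 percentage points apart, beyond the scatter of two such steps This rests on a single pair for each core and does not show which part of the cores goes with the reversal, or why it occurs.

The compounds shown carry only methoxy groups on this phenyl ring. From the compounds shown here alone, how a hydroxyl group or an amine at that place would behave on either core remains open.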